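The source may report more compounds than this note shows. Statements on the series, on what has been measured and on what is new or still open speak of the compounds shown alone.

Compound 1 `O=C(NC(=S)NNc1ncnc2ccccc12)c1ccccc1F` gives 6460 nM.
Compound 2 `COc1cc2ncnc(NNC(=S)NC(=O)c3ccccc3F)c2cc1OC` gives 8640 nM.
Compound 3 `O=C(NC(=S)NNc1ncnc2ccccc12)c1ccccc1` gives 8370 nM.

In a functional assay on GLC82 cells (Homo sapiens) for cytotoxicity, read by MTT assay, with a stated time of 72 h (on this read-out lower numbers stand for stronger inhibition and higher numbers for weaker inhibition), compound 3 shows the second highest of the three numbers; its nearest neighbour is compound 2 and its furthest compound 1, and both gaps lie within the scatter, so none of the three stands apart. Compound 4 `O=C(NC(=S)NNc1ncnc2ccccc12)c1cccc(Cl)c1` differs from compound 3 by chloro in place of hydrogen on an aromatic carbon, phenyl to 3-chlorophenyl. Going by the values given here, the only measured step on this ring is a 1.3-fold higher number from compound 1 to compound 3 (0.11 log units; within the scatter), a swap of a halogen for hydrogen that left the number essentially unchanged. Nothing measured bears on a chloro at this place. Compound 4 is therefore expected to give about 6500 nM, within 2500 nM to 17000 nM. The expected step is a 1.3-fold lower number from compound 3 to compound 4 (0.11 log units; within the scatter), not beyond the scatter.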

Compound 4, half-maximal inhibitory concentration: 3240 nM
The estimate for compound 4 lay 2.0-fold (0.30 log units) above the measured number, and the stated range covers the measured number.
By their numbers in this assay, from the lowest: compounds 4, 1, 3 and 2 (each within the scatter of the next, the first and the last beyond it).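

In this assay, going by these compounds alone, chloro in place of hydrogen gives a 2.6-fold lower number from compound 3 to compound 4 (0.41 log units; beyond the scatter) and so is the first change on this ring that lies beyond the scatter. Replacing 2-fluorophenyl with 3-chlorophenyl gives a 2.0-fold lower number from compound 1 to compound 4 (0.30 log units; within the scatter) and so does not separate these two halogen-bearing compounds. Nothing measured here explains the effect of the chloro.

As far as these compounds go, it remains open whether a methoxy or an amine in the same place would give a similar number. From the compounds shown here alone, it is also open whether 3-chlorophenyl would lower the number on the core of compound 2.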